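Pyrazole series: amide versus urea on the anilide carbon

The source may hold more compounds than are shown below. What is called first, only, known or untested is meant among the compounds shown, and "the series" means these compounds.

Measured so far:
compound 1 `COc1cc(-c2nn(-c3cccc(NC(=O)c4cccc(C(F)(F)F)c4)c3)cc2-c2ccncc2)ccc1Cl`, a functional assay on COLO 205 cells (Homo sapiens) for inhibition, read by sulforhodamine B assay, with a stated time of 48 h (a higher number here means that more compound is tolerated, a lower number that less compound is tolerated), 24800 nM
compound 2 `COc1cc(-c2nn(-c3cccc(NC(=O)Nc4ccc(Cl)c(C(F)(F)F)c4)c3)cc2-c2ccncc2)ccc1Cl`, this assay 3480 nM

For the measured compounds named here, compound 2 holds the lower of the two numbers; its only neighbour is compound 1, with the step of a 7.1-fold lower number from compound 1 to compound 2 (0.85 log units; beyond the scatter) separating them beyond the scatter. Compound 3 `COc1cc(-c2nn(-c3cccc(NC(=O)c4ccccc4)c3)cc2-c2ccncc2)ccc1Cl` has not been measured. It differs from compound 2 in one place: phenyl in place of (4-chloro-3-(trifluoromethyl)phenyl)amino on a carbonyl carbon. Going by the values given here, only the step from compound 1 to compound 2 bears on this change, and it ran in the opposite sense, from an amide without a halogenated aryl nitrogen toward the urea. Compound 3 goes back to an amide and also drops the trifluoromethyl carried by compound 1, so the step is expected to undo that gain and probably exceed it. Compound 3 is estimated at 40000 nM, range 15000 nM to 100000 nM, corresponding to an expected step of an 11-fold higher number from compound 2 to compound 3 (1.06 log units; beyond the scatter).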

Compound 3, concentration lethal to 50% of the cells: 68400 nM
Beside the measured number, compound 3's estimate is 1.7-fold (0.23 log units) below it; the measured number falls inside the stated range.
By their numbers in this assay, from the lowest: compound 2; then compound 1; then compound 3.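

In this assay the trifluoromethyl now has a reading of its own on the amide, since hydrogen in its place on an aromatic carbon gives a 2.8-fold higher number from compound 1 to compound 3 (0.44 log units; beyond the scatter) with nothing else changed. The full change on the carbonyl carbon is much larger, with phenyl in place of (4-chloro-3-(trifluoromethyl)phenyl)amino giving a 20-fold higher number from compound 2 to compound 3 (1.29 log units; beyond the scatter) in the same direction. The trifluoromethyl step therefore covers only part of that distance, and the rest stays unassigned. The amino nitrogen and the chlorine change together.

From the compounds shown here alone, whether the nitrogen or the chlorine carries that remainder stays open, as does whether a nitrile or a methoxy on that aromatic carbon would read like trifluoromethyl or like hydrogen. No data at hand account for either step.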